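The source may report more compounds than this note shows. Statements on the series, on what has been measured and on what is new or still open speak of the compounds shown alone.

Compound 1 `Cn1nnnc1SCC(=O)N/N=C/c1ccccc1` in an ADME assay on NIH3T3 cells (Mus musculus) for cytotoxicity, read by XTT assay, with a stated time of 24 h (on this read-out higher numbers stand for weaker inhibition and lower numbers for stronger inhibition), gives 9700000 nM.
Compound 2 `Cn1nnnc1SCC(=O)N/N=C/c1ccc([N+](=O)[O-])cc1` in this assay gives 9300000 nM.
Compound 3 `Cc1ccc(/C=N/NC(=O)CSc2nnnn2C)cc1` in this assay gives 3160000 nM.

Compound 3 gives the lowest number of the measured compounds: the steps of a 3.1-fold lower number from compound 1 to compound 3 (0.49 log units; beyond the scatter) and a 2.9-fold lower number from compound 2 to compound 3 (0.47 log units; beyond the scatter) are both beyond the scatter, while the step of a 1.0-fold lower number from compound 1 to compound 2 (0.02 log units; within the scatter) is within it. Compound 4 `CC(C)c1ccc(/C=N/NC(=O)CSc2nnnn2C)cc1` differs from compound 3 only by the change (isopropyl in place of methyl on an aromatic carbon). Among the compounds with values here, the steps that bear on this are those leading to compound 3, where a methyl entered on the same ring and the number fell modestly; no measured pair shows a change from methyl to a larger alkyl group. A further modest fall is therefore expected, as the step of a 2.1-fold lower number from compound 3 to compound 4 (0.32 log units; beyond the scatter). Compound 4 is expected to give 1500000 nM, with a range from 500000 nM to 5000000 nM.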

Compound 4, half-maximal inhibitory concentration: 1200000 nM
Beside the measured number, compound 4's estimate is 1.3-fold (0.10 log units) above it, within the range that was stated.
By their numbers in this assay, from the lowest: compound 4; then compound 3; then compounds 2 and 1 (each within the scatter of the next).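

In this assay, a larger alkyl group at this ring position lowers the number again (a 2.6-fold lower number from compound 3 to compound 4 (0.42 log units; beyond the scatter)), as isopropyl with its 3 carbons replaces methyl with its 1. The earlier compounds shown here showed only a change from hydrogen or nitro to methyl, whereas the isopropyl compound stands further from both (an 8.1-fold lower number from compound 1 to compound 4 (0.91 log units; beyond the scatter); a 7.8-fold lower number from compound 2 to compound 4 (0.89 log units; beyond the scatter)). No measurement here offers an explanation for these falls. On these data alone, whether a longer chain such as n-butyl would lower the number further, and what an amine or a carboxylic acid would do here, remains open.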